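Ethoxy placement on the aryl-amino arm of the shared core

This account rests on a few compounds, and the source may have more. Where it says the series, first, only, none or still open, it means among the compounds named here.

Within the data shown here, compound 3 `CCOc1ccccc1Nc1nc2nonc2nc1Nc1ccccc1F` carries 2-ethoxyphenyl on a nitrogen on an aromatic ring; in an assay on mitochondria from L6 cells (Rattus norvegicus) for activation, with a stated time of 90 min (on this read-out lower numbers stand for an effect already at smaller amounts and higher numbers for an effect only at larger amounts of compound), compound 3 gives 5600 nM, the highest of the three numbers measured so far. Compound 1 `Fc1ccccc1Nc1nc2nonc2nc1Nc1ccccc1` gives 2200 nM and compound 2 `Cc1cccc(Nc2nc3nonc3nc2Nc2ccccc2F)c1` gives 1500 nM in this assay. The steps into compound 3 are a 2.5-fold higher number from compound 1 to compound 3 (0.41 log units; beyond the scatter) and a 3.7-fold higher number from compound 2 to compound 3 (0.57 log units; beyond the scatter), whereas a 1.5-fold lower number from compound 1 to compound 2 (0.17 log units; within the scatter). Compound 4 `CCOc1ccc(Nc2nc3nonc3nc2Nc2ccccc2F)cc1` has the same atoms joined differently: 4-ethoxyphenyl in place of 2-ethoxyphenyl on a nitrogen on an aromatic ring. Among the measured compounds shown here, no measured pair moves an ethoxy group from one position to another on this ring, so the bearing steps are only indirect: 2-ethoxyphenyl sits at the weak end of the series, and ethoxy in place of hydrogen cost a modest amount in a 2.5-fold higher number from compound 1 to compound 3 (0.41 log units; beyond the scatter). Compound 4 is expected to recover part of that loss and to give 3000 nM in this assay, within a range from 1000 nM to 9000 nM. The expected step is a 1.9-fold lower number from compound 3 to compound 4 (0.27 log units; within the scatter), small enough that it may fall within the scatter.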

Compound 4, half-maximal effective concentration: 3800 nM
The estimate for compound 4 lay 1.3-fold (0.10 log units) below the measured number; the range from low to high includes it.
By their numbers in this assay, from the lowest: compounds 2, 1, 4 and 3 (each within the scatter of the next, the first and the last beyond it).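

Among these compounds, this pair is the first to move the ethoxy group around this ring: in this assay, 4-ethoxyphenyl in place of 2-ethoxyphenyl gives a 1.5-fold lower number from compound 3 to compound 4 (0.17 log units; within the scatter), so the two arrangements cannot be told apart. Ethoxy in place of hydrogen also no longer reads as a clear cost, since the 4-ethoxyphenyl compound shows a 1.7-fold higher number from compound 1 to compound 4 (0.24 log units; within the scatter), whereas the same kind of change in compound 3 went beyond the scatter. Against the 3-methylphenyl arm the separation remains, with a 2.5-fold higher number from compound 2 to compound 4 (0.40 log units; beyond the scatter) as a modest step.

Going by these compounds, whether an amine or a carboxylic acid on this ring in place of ethoxy would shift the number beyond the scatter stays open. No measurement at hand speaks to the reason for these steps.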